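Series notes: aryl side-chain changes on a shared core

This account rests on a few compounds, and the source may have more. Where it says the series, first, only, none or still open, it means among the compounds named here.

Measured so far:
compound 1 `C=C[C@@](C)(/C=C/c1ccc(Nc2ccc(OC)cc2)cc1)CCC=C(C)C`: > 36600 nM, a limit of the assay
compound 2 `C=C[C@@](C)(/C=C/c1ccc(Nc2cc(F)c(F)c(F)c2)cc1)CCC=C(C)C`: > 36600 nM, a limit of the assay

In a functional assay on SEM cells (Homo sapiens) for cytotoxicity, with a stated time of 72 h (on this read-out higher numbers stand for an effect only at larger amounts of compound and lower numbers for an effect already at smaller amounts), compound 1 stands at the limit of the assay. Compound 2 likewise sits at the limit; the step that the two limits leave unreadable from compound 1 to compound 2 is therefore of no readable size, and both values rest on (the limit of > 36600 nM in this assay, at which 2 of the 2 values shown sit).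

Compound 3 `C=C[C@@](C)(/C=C/c1ccc(-c2ccccc2)cc1)CCC=C(C)C` differs from compound 1 by phenyl in place of (4-methoxyphenyl)amino on an aromatic carbon. Among the measured compounds shown here, no measured step bears directly on this change; the only step in hand, from compound 1 to compound 2, is unreadable. With nothing below the limit anywhere in the series, compound 3 is expected to stay near it as well: the estimate is 40000 nM, within 12000 nM to 120000 nM, which means an expected step that the limit leaves unreadable from compound 1 to compound 3.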

Compound 3, half-maximal effective concentration: > 36600 nM
Compound 3: no number, only a limit; the forecaster's own chance of this, stated with the estimate: 70%; the middle value is on the limit's open side.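

Compound 3 sits at the same limit as compound 1 and compound 2, so no step among these compounds can be read: the limit of > 36600 nM in this assay, at which 3 of the 3 values shown sit.

The compounds shown leave open whether any aryl side-chain change on the shared core gives a value off this limit.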